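The source may report more compounds than this note shows. Statements on the series, on what has been measured and on what is new or still open speak of the compounds shown alone.

Measured so far, each compound with its result in a functional assay on the whole organism (strain Kunming) with Mus musculus as the target, with a stated time of 0.5 h, at a dose of 100 mg/kg by the intraperitoneal route; on this read-out lower numbers stand for a stronger effect and higher numbers for a weaker effect at the one dose given:

compound 1, `COc1cc(OC)c(OC)cc1/C=C/COC(=O)/C=C/c1ccc(OC)c(OC)c1OC`: 100%
compound 2, `COc1cc(OC)c(OC)cc1/C=C/COC(=O)/C=C/c1cccc(Br)c1`: 100%
compound 3, `COc1cc(OC)c(OC)cc1/C=C/COC(=O)/C=C/c1cc(OC)c(OC)c(OC)c1OC`: 100%

All three compounds share one core and differ only in the ring carried on the double-bonded chain. On the numbers shown, compound 2 stands level with compound 1 and with compound 3; none of these values is separated from another by more than the usual scatter, so no order among them can be read.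

The step to the unmeasured compound 4, `COc1cc(OC)c(OC)cc1/C=C/COC(=O)/C=C/c1ccccc1Cl`, changes this ring once more: 2-chlorophenyl in place of 3-bromophenyl on a double-bonded chain carbon bound to a double-bonded chain carbon

Among the measured compounds shown here, only one measured step exists, and it concerns a different kind of change, an added methoxy on an aromatic carbon: no change at the digits printed from compound 1 to compound 3 (within the scatter). For the measured compounds named here, no measured pair swaps one halogen for another or moves a halogen on the ring, so no step speaks directly to the change from compound 2 to compound 4. What the three measured compounds do show is that three quite different rings in this position all give the same reading in this assay. On that basis the expected step is none beyond the scatter: no change at the digits printed from compound 2 to compound 4 (within the scatter).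

Compound 4 is therefore estimated at 100%, with a range from 85% to 100%.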

Compound 4, a percentage reported as activity, at one dose (the size of the read-out at that dose, not a potency): 100%
Compound 4: the middle estimate sits on the measured number at the digits printed, and the stated range covers the measured number.
By their numbers in this assay, from the lowest: compounds 1, 2, 3 and 4 (each within the scatter of the next).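

In this assay the exchange of 3-bromophenyl for 2-chlorophenyl gives no change at the digits printed from compound 2 to compound 4 (within the scatter) and is the only step shown in which the halogen and its place on the ring change together. A halogen-bearing ring with chlorine now reads the same as the bromine-bearing ring of compound 2, so the change of halogen and the change of its place show no combined effect at this dose, although one step cannot separate the two changes or rule out that they cancel each other. No measurement shown here offers an explanation for this flat result.

Because all the rings shown are phenyl rings bearing methoxy or halogen groups, it remains open whether an amine or a carboxylic acid on the ring, or a cyclohexyl group in its place, would shift the reading in this assay at all. Also open, going by these compounds, is what 3-chlorophenyl or 2-bromophenyl would give, since those groups would test the halogen and its place one at a time.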